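The source may report more compounds than this note shows. Statements on the series, on what has been measured and on what is new or still open speak of the compounds shown alone.

Measured so far:
compound 1 `O=C(NCc1ccccc1)c1nc(Cc2ccccc2C(F)(F)F)[nH]c(=O)c1O` — > 100000 nM, a limit of the assay.
compound 2 `Cn1c(Cc2ccccc2C(F)(F)F)nc(C(=O)NCc2ccc(F)cc2)c(O)c1=O` — > 100000 nM, also a limit.

In an ADME assay on HepG2 cells (Homo sapiens) for cytotoxicity, in the presence of a further agent that is not named here (on this read-out lower numbers stand for stronger inhibition and higher numbers for weaker inhibition), compound 1 gives only a limit and no number. Among the compounds with values here, the one further value shown is likewise a limit. Both sit at the limit of > 100000 nM in this assay, at which 2 of the 2 values shown sit. Compound 3 `Cn1c(Cc2ccccc2C(F)(F)F)nc(C(=O)NCc2ccccc2)c(O)c1=O` differs from compound 1 by methyl in place of hydrogen on an aromatic nitrogen. Within the data shown here, no step between measured compounds is available. In this assay no step beyond the scatter is expected, as compound 2, which also carries the methyl, reports a limit. Compound 3 is expected to give about 150000 nM, between 80000 nM and 400000 nM. The expected step is a step that the limit leaves unreadable from compound 1 to compound 3, within the scatter, most likely again reported as a limit.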

Compound 3, half-maximal inhibitory concentration: > 100000 nM
Compound 3 ended at the assay's limit; the forecaster's own chance of this, stated with the estimate: 85%; the middle value is on the limit's open side.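

No step can be read among compound 1, compound 2 and compound 3 in this assay: the limit of > 100000 nM in this assay, at which 3 of the 3 values shown sit.

Whether the methyl or the fluoro changes the read-out at all stays open, with no number among the compounds shown.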